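Tetrahydropyrrolopyridinone acetic acids: triazolylmethyl to hydroxybenzyl swap

The source may report more compounds than this note shows. Statements on the series, on what has been measured and on what is new or still open speak of the compounds shown alone.

Measured so far in a functional assay on CHO.K1 cells for antagonist activity at prostaglandin D2 receptor 2 (Homo sapiens), read by GTPgammaS binding, with a stated time of 1 h; a lower number here means a stronger inhibitor, a higher number a weaker inhibitor:
compound 1 `Cc1c(Cc2ccccc2S(=O)(=O)c2cccc(Cl)c2)c2c(n1CC(=O)O)CCNC2=O`, 4 nM
compound 2 `Cc1c(Cc2ccccc2S(=O)(=O)C2CCCCC2)c2c(n1CC(=O)O)CCNC2=O`, 28 nM
compound 3 `Cc1c(Cc2ccccc2Cn2ccnn2)c2c(n1CC(=O)O)CCNC2=O`, 800 nM

Compound 3 gives the highest number of the three in this assay, with compound 2 nearest and compound 1 furthest; both gaps lie beyond the scatter, so compound 3 is the weakest inhibitor of the set.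

Compound 4 `Cc1c(Cc2ccccc2C(O)c2ccccc2)c2c(n1CC(=O)O)CCNC2=O` differs from compound 3 by hydroxy(phenyl)methyl in place of (1H-1,2,3-triazol-1-yl)methyl on an aromatic carbon; the entering group carries one six-membered carbon-only aromatic ring and one hydrogen-bond donor where the leaving group had a five-membered ring with three heteroatoms and no donor.

Going by the values given here, two measured steps bear on this position. Going from the (3-chlorophenyl)sulfonyl group to the triazolylmethyl group cost a 200-fold higher number from compound 1 to compound 3 (2.30 log units; beyond the scatter), and from the cyclohexylsulfonyl group a 29-fold higher number from compound 2 to compound 3 (1.46 log units; beyond the scatter). Both show that the triazolylmethyl substituent is the poorest of the three groups placed here, and that a ring bound through a one-atom linker is tolerated far better. Compound 4 returns a six-membered carbon ring through a one-carbon linker, though with a hydroxyl instead of a sulfonyl link; the aryl sulfonyl of compound 1 and the alkyl sulfonyl of compound 2 differ by only a 7.0-fold higher number from compound 1 to compound 2 (0.85 log units; beyond the scatter), so the linker itself is not fully decisive. A recovery toward compound 1 and compound 2 is therefore expected, but an incomplete one, giving an expected step of an 8.0-fold lower number from compound 3 to compound 4 (0.90 log units; beyond the scatter). Compound 4 is estimated at 100 nM in this assay, within 20 nM to 500 nM.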

Compound 4, half-maximal inhibitory concentration: 32 nM
Estimate against measurement, compound 4: 3.1-fold (0.49 log units) above, and the stated range covers the measured number.
By their numbers in this assay, from the lowest: compound 1; then compounds 2 and 4 (each within the scatter of the next); then compound 3.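

Working notes: in this assay, the exchange of (1H-1,2,3-triazol-1-yl)methyl for hydroxy(phenyl)methyl gives a 25-fold lower number from compound 3 to compound 4 (1.40 log units; beyond the scatter), so on this aromatic carbon, ortho to a large group, a sulfonyl link is not required for a number well clear of compound 3. The hydroxy(phenyl)methyl group also cannot be told apart from cyclohexylsulfonyl, with a 1.1-fold higher number from compound 2 to compound 4 (0.06 log units; within the scatter), whereas the (3-chlorophenyl)sulfonyl group keeps its lead, with an 8.0-fold higher number from compound 1 to compound 4 (0.90 log units; beyond the scatter); that last exchange alters both the link and the chlorine on the ring, so the gap cannot be assigned to either one alone. Nothing measured here accounts for these differences.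

Open, going by these compounds, is what the hydroxyl itself contributes, a question that a plain methylene or a carbonyl link to the same phenyl ring would address. Also open, on these data alone, is whether a chlorine on the phenyl ring of the hydroxy(phenyl)methyl group would bring the number toward that of compound 1.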